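This account rests on a few compounds, and the source may have more. Where it says the series, first, only, none or still open, it means among the compounds named here.

Compound 1 `CCSc1nnc(-c2cc(OC)c(OC)c(OC)c2)n1-c1ccc(OC)cc1`: in a functional assay on HT-29 cells (Homo sapiens) for inhibition, read by MTT assay, with a stated time of 48 h (a higher number here means a weaker inhibitor, a lower number a stronger inhibitor), compound 1 gives > 60000 nM, which is a limit of the assay and not a number.
Compound 2 `COc1ccc(-n2c(SCc3ccc(C)cc3)nnc2-c2cc(OC)c(OC)c(OC)c2)cc1`: in this assay compound 2 gives > 60000 nM, again a limit and not a number.
Compound 3 `COc1ccc(-n2c(SCc3ccc(F)cc3)nnc2-c2cc(OC)c(OC)c(OC)c2)cc1`: in this assay compound 3 gives 50700 nM.

Compound 2 therefore stands at the limit; nothing beyond that is known of it, and the same holds for compound 1. For the measured compounds named here, compound 3 is the only measured compound with a numerical value, and it sits close to that limit, as the limit of > 60000 nM in this assay, at which 2 of the 3 values shown sit, shows. The unmeasured compound 4 `COc1ccc(-n2c(SCC(=O)Nc3ccc(Cl)cc3)nnc2-c2cc(OC)c(OC)c(OC)c2)cc1` differs from compound 2 in one place: (4-chlorophenyl)carbamoyl in place of 4-methylphenyl on a saturated chain carbon bound to a sulfur.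

Among the measured steps, an at least 1.1-fold lower number from compound 2 to compound 3 (0.07 log units; that floor lies within the scatter), an at least 1.1-fold lower number from compound 1 to compound 3 (0.07 log units; that floor lies within the scatter), and a step that the two limits leave unreadable from compound 1 to compound 2. None of them alters the group in the way compound 4 does, so they give no direct guide; what they share is that every value sits at or close to the limit. The expectation for compound 4 is a weak inhibitor as well, with an at least 1.2-fold lower number from compound 2 to compound 4 (0.07 log units; that floor lies within the scatter) meaning no clear step beyond the scatter. Compound 4 is estimated at 50000 nM, within 15000 nM to 60000 nM, with a fair chance that only a limit is reported.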

Compound 4, half-maximal inhibitory concentration: 58000 nM
Compound 4: the middle estimate sits 1.2-fold (0.06 log units) below what was measured, and the stated range covers the measured number.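

At the saturated chain carbon bound to a sulfur, (4-chlorophenyl)carbamoyl brings a carbonyl, an amide hydrogen and a chlorine, with a hydrogen-bond donor and acceptor that 4-methylphenyl lacks, and in this assay the swap from 4-fluorophenyl gives a 1.1-fold higher number from compound 3 to compound 4 (0.06 log units; within the scatter). The comparisons with the other two compounds read an at least 1.0-fold lower number from compound 2 to compound 4 (0.01 log units; that floor lies within the scatter) and an at least 1.0-fold lower number from compound 1 to compound 4 (0.01 log units; that floor lies within the scatter), so none of the three steps is shown to leave the usual scatter. The earlier compounds could not show that a group carrying a hydrogen-bond donor and acceptor at this position also leaves the value close to the limit of the assay: the limit of > 60000 nM in this assay, at which 2 of the 4 values shown sit.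

As far as these compounds go, it remains open whether any group at this position can move the number clear of the scatter, and whether the carbonyl, the amide hydrogen or the chlorine matters on its own. An amine or a carboxylic acid at the same place, or a longer chain ending in (4-chlorophenyl)carbamoyl, would be needed to begin answering that.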